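The source may report more compounds than this note shows. Statements on the series, on what has been measured and on what is new or still open speak of the compounds shown alone.

Measured so far in an ADME assay for permeability, using PAMPA, with a stated time of 30 min, at pH 7.4; on this read-out lower numbers stand for lower permeability and higher numbers for higher permeability:
- compound 1 `COc1ccc(-c2ccc3c(NCCCNCc4ccco4)ccnc3c2)cc1`: 237 10^-6 cm/s
- compound 2 `c1ccc(CCc2ccc3c(NCCCNCc4ccco4)ccnc3c2)cc1`: 23 10^-6 cm/s
- compound 3 `CC(C)(C)c1ccc(-c2ccc3c(NCCCNCc4ccco4)ccnc3c2)cc1`: 237 10^-6 cm/s

Compound 3 stands level with compound 1 at the digits printed, the two together giving the highest numbers of the three; compound 2 sits well apart, a 10-fold higher number from compound 2 to compound 3 (1.01 log units; beyond the scatter).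

All three measured compounds differ only in the group carried on the same aromatic carbon of the shared core. Within the data shown here, two steps bear on the step to compound 4: no change at the digits printed from compound 1 to compound 3 (within the scatter), and a 10-fold lower number from compound 1 to compound 2 (1.01 log units; beyond the scatter). Swapping one substituent on the outer aromatic ring for another left the read-out unchanged, while replacing the whole aryl group by phenethyl gave a large drop.

Compound 4 `CN(C)c1cccc(Oc2ccc3c(NCCCNCc4ccco4)ccnc3c2)c1` carries instead a group not represented among the measured compounds: 3-(dimethylamino)phenoxy in place of 4-(tert-butyl)phenyl on an aromatic carbon. Among the measured compounds shown here, the group entering keeps a six-membered aromatic ring, so the change is closer in kind to the step from compound 1 to compound 3 than to the step to compound 2; no measured step covers the switch from a directly attached aryl to an aryloxy group, nor the dimethylamino substituent. The expectation for this assay is therefore a small step, most likely downward and possibly within the scatter, a 1.8-fold lower number from compound 3 to compound 4 (0.26 log units; within the scatter).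

Estimated for compound 4 in this assay: 130 10^-6 cm/s, range 50 10^-6 cm/s to 260 10^-6 cm/s.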

Compound 4, apparent permeability: 317 10^-6 cm/s
Estimate against measurement, compound 4: 2.4-fold (0.39 log units) below, outside the stated range (above it).
By their numbers in this assay, from the lowest: compound 2; then compounds 1, 3 and 4 (each within the scatter of the next).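

At this position, in this assay, a 3-(dimethylamino)phenoxy group takes the place of an aryl group attached directly to the core with a 1.3-fold higher number from compound 3 to compound 4 (0.13 log units; within the scatter) and with a 1.3-fold higher number from compound 1 to compound 4 (0.13 log units; within the scatter) as well, so compounds 1, 3 and 4 form one level even though the group entering brings an oxygen link, a nitrogen and 2 hydrogen-bond acceptors against 0 in 4-(tert-butyl)phenyl. Among the four compounds, only phenethyl stands apart, with a 14-fold higher number from compound 2 to compound 4 (1.14 log units; beyond the scatter) as the large step, and this extends the gap first seen for compound 2 to a group attached through oxygen. Nothing available explains why the read-out stays level across these groups or why compound 2 falls away.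

The oxygen link and the dimethylamino group enter together in compound 4, so their separate contributions cannot be read, and an unsubstituted phenoxy group would be needed to separate them. Also open, from the compounds shown here alone, is how the read-out responds at this position to a carboxylic acid on the six-membered aromatic ring, or to a longer chain than phenethyl.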